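The compounds below may be only part of what the source reports. "The series", "measured", "known", "first", "only" and "open" are said of these compounds alone.

Measured in a functional assay on K562 cells (Homo sapiens) for antiproliferative activity, read by MTT assay, with a stated time of 72 h; on this read-out higher numbers stand for weaker inhibition and lower numbers for stronger inhibition:

Compound 1 `COc1ccc(-c2ncnn2-c2cc(OC)c(OC)c(OC)c2)cc1`: 950 nM
Compound 2 `COc1cc(-n2ncnc2-c2ccc(Cl)c(Cl)c2)cc(OC)c1OC`: > 10000 nM, a limit of the assay and not a number
Compound 3 `CCOc1cccc(-c2ncnn2-c2cc(OC)c(OC)c(OC)c2)c1`: > 10000 nM, a limit of the assay and not a number

Among the measured compounds shown here, compound 1, at 950 nM, is the only compound here with a true number in this assay. The other two compounds stand at the limit of > 10000 nM in this assay, at which 2 of the 3 values shown sit. Between compound 1 and compound 3, the values show only a number set against a limit.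

Compound 4 `COc1cc(-n2ncnc2-c2ccc(OC(C)C)cc2)cc(OC)c1OC` has not yet been measured. It departs from compound 1 by isopropyl in place of methyl on an oxygen on an aromatic ring, which is isopropyl in place of methyl on an oxygen on an aromatic ring, or methoxy to isopropoxy.

For the measured compounds named here, no measured step makes this exact change. The nearest evidence is an at least 10-fold higher number from compound 1 to compound 2 (1.02 log units; beyond the scatter), a large step that replaces the whole 4-methoxyphenyl with 3,4-dichlorophenyl. It shows that activity in compound 1 can be lost through a change at this group, but it cannot give the size of a smaller edit. A step towards a higher number, and so weaker inhibition, is therefore expected in this assay, though probably a smaller one. The expected change is a 3.2-fold higher number from compound 1 to compound 4 (0.50 log units; beyond the scatter). The estimate for compound 4 is 3000 nM, with an expected range of 600 nM to 10000 nM.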

Compound 4, half-maximal inhibitory concentration: 800 nM
Estimate against measurement, compound 4: 3.8-fold (0.57 log units) above, within the range that was stated.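

In this assay, methoxy to isopropoxy gives a 1.2-fold lower number from compound 1 to compound 4 (0.07 log units; within the scatter), so compound 1 and compound 4 cannot be told apart, and the oxygen on the aromatic ring carries isopropyl as well as it carries methyl. The earlier compounds had shown only that activity could be lost at this group, when the whole 4-methoxyphenyl gave way to 3,4-dichlorophenyl in an at least 10-fold higher number from compound 1 to compound 2 (1.02 log units; beyond the scatter); compound 4 shows that such a loss does not follow from every edit there, and that the larger alkyl group on the oxygen is tolerated in this cell read-out. Compound 2 and compound 3 remain a limit of the assay and not a number: the limit of > 10000 nM in this assay, at which 2 of the 4 values shown sit.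

As far as these compounds go, a single pair cannot show how far the group on this oxygen can grow, so it remains open whether a cyclopentyl or benzyl group there would leave the read-out as it stands, or whether a free hydroxyl would do so. Also open, from the compounds shown here alone, is what an amine or a carboxylic acid would do at the end of a longer chain on the same oxygen.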